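Replacing the aryl group of compound 2

The source may report more compounds than this note shows. Statements on the series, on what has been measured and on what is new or still open speak of the compounds shown alone.

Compound 1 `O=C(O)c1cc(F)c2nc(N3CCC4(C=C(c5c(-c6ccccc6C(F)(F)F)noc5C5CC5)C4)CC3)sc2c1` shows > 2 h and this is a limit of the assay, not a number
Compound 2 `O=C(O)c1cc(F)c2nc(N3CCC4(C=C(c5c(-c6ccccc6OC(F)(F)F)noc5C5CC5)C4)CC3)sc2c1` shows 1.52 h as a measured number
Compound 3 `O=C(O)c1cc(F)c2nc(N3CCC4(CC3)CC(c3c(-c5c(Cl)cccc5Cl)noc3C3CC3)C4)sc2c1` shows 1.53 h as a measured number

In an ADME assay on microsomes from liver (Mus musculus) for metabolic stability (a higher number here means that the compound lasts longer, a lower number that the compound disappears faster), compound 2 lies within the scatter of compound 3. Compound 4 `O=C(O)c1cc(F)c2nc(N3CCC4(C=C(c5c(-c6c(Cl)cncc6Cl)noc5C5CC5)C4)CC3)sc2c1` carries 3,5-dichloropyridin-4-yl in place of 2-(trifluoromethoxy)phenyl on an aromatic carbon and otherwise matches compound 2. Going by the values given here, one measured step bears on this place, an at least 1.3-fold lower number from compound 1 to compound 2 (0.11 log units; that floor lies within the scatter) and it too exchanges one group there for another. Its floor lies within the scatter, so no step beyond the scatter is expected here. The expected step is a 1.0-fold lower number from compound 2 to compound 4 (0.01 log units; within the scatter) and it would be too small to tell from repeat measurements. For compound 4 the estimate is 1.5 h with an expected range from 0.8 h to 2 h in this assay.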

Compound 4, half-life: > 2 h
Compound 4 gave a limit, no number; the forecaster's own chance of this, stated with the estimate: 25%; middle value at least 1.3-fold (0.12 log units) away from the limit.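

In this assay, putting 3,5-dichloropyridin-4-yl in place of 2-(trifluoromethoxy)phenyl gives an at least 1.3-fold higher number from compound 2 to compound 4 (0.11 log units; that floor lies within the scatter). Going by these compounds, compound 4 gives > 2 h, which is a limit of the assay, so this place accepts a six-membered aromatic ring with 1 hetero atom, but the true size of the step stays unknown. The step between compound 1 and compound 4 cannot be read, and the result rests on a shared limit: the limit of > 2 h in this assay, at which 2 of the 4 values shown sit.

On these data alone, how an aryl group carrying an amine or a carboxylic acid would fare at this place remains open.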